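The source may hold more compounds than are shown below. What is called first, only, known or untested is meant among the compounds shown, and "the series" means these compounds.

Compound 1 `CC1CC/C(=N\Nc2ccccc2O)c2ncc(C(=O)O)c(=O)n21` and compound 2 `CCOc1cccc(N/N=C2\CCC(C)n3c2ncc(C(=O)O)c3=O)c1` share one core and differ only in a group attached to it. In a functional assay on the whole organism for inhibition, with Rattus norvegicus as the target (on this read-out lower numbers stand for an effect already at smaller amounts and higher numbers for an effect only at larger amounts of compound), compound 1 gives 0.26 umol/kg and compound 2 gives 0.2 umol/kg, the lower of the two numbers, though the gap to compound 1 lies within the usual scatter of this measurement. Compound 3 `Cc1cccc(N/N=C2\CCC(C)n3c2ncc(C(=O)O)c3=O)c1` is not yet measured; it differs from compound 2 by methyl in place of ethoxy on an aromatic carbon. Within the data shown here, no measured step for such a change exists here, so compound 3 is expected to sit near its neighbour, and a 1.5-fold higher number from compound 2 to compound 3 (0.18 log units; within the scatter) in this assay is estimated as no step beyond the scatter. The estimate for compound 3 is 0.3 umol/kg, with a range from 0.1 umol/kg to 0.9 umol/kg.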

Compound 3, dose for 50% inhibition: 0.4 umol/kg
Compound 3: the middle estimate sits 1.3-fold (0.12 log units) below what was measured; the range from low to high includes it.
By their numbers in this assay, from the lowest: compounds 2, 1 and 3 (each within the scatter of the next).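

On an aromatic carbon meta to a large group, methyl in place of ethoxy gives a 2.0-fold higher number from compound 2 to compound 3 (0.30 log units; within the scatter) in this assay and so does not move the number beyond the scatter. Replacing the whole 2-hydroxyphenyl with 3-methylphenyl on the amine nitrogen gives a 1.5-fold higher number from compound 1 to compound 3 (0.19 log units; within the scatter) and also stays inside it. Nothing here gives a cause for either result. On these data alone, whether an amine or a longer chain such as propoxy on this aromatic carbon would shift the number beyond the scatter remains open.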